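The compounds below may be only part of what the source reports. "The series", "measured", "known", "first", "only" and "open" are said of these compounds alone.

In a functional assay on PC-3 cells (Homo sapiens) for antiproliferative activity, read by sulforhodamine B assay, with a stated time of 72 h (a higher number here means a weaker inhibitor, a lower number a stronger inhibitor), compound 1 `COc1ncc(-c2ccc3ncc(NC(=O)C4CCCCC4)c(OC)c3c2)cc1NS(=O)(=O)c1ccc(F)cc1F` gives 6630 nM, compound 2 `CCNc1cnc2ccc(-c3cnc(OC)c(NS(=O)(=O)c4ccc(F)cc4F)c3)cc2c1OC` gives 4820 nM, and compound 3 `COc1ccc(CNc2cnc3ccc(-c4cnc(OC)c(NS(=O)(=O)c5ccc(F)cc5F)c4)cc3c2OC)cc1` gives 4520 nM. Compound 3 therefore stands within the usual scatter of both other compounds, and the numbers do not separate the three.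

The next structure, compound 4 `COc1ncc(-c2ccc3ncc(NC(=O)CN4CCCC(O)C4)c(OC)c3c2)cc1NS(=O)(=O)c1ccc(F)cc1F`, carries ((3-hydroxypiperidin-1-yl)methyl)carbonyl in place of 4-methoxybenzyl on a nitrogen on an aromatic ring.

Three measured steps changed the group on this same nitrogen or its chain. Exchanging cyclohexylcarbonyl for ethyl gave a 1.4-fold lower number from compound 1 to compound 2 (0.14 log units; within the scatter), and exchanging it for 4-methoxybenzyl gave a 1.5-fold lower number from compound 1 to compound 3 (0.17 log units; within the scatter). Exchanging methyl for 4-methoxyphenyl on the chain gave a 1.1-fold lower number from compound 2 to compound 3 (0.03 log units; within the scatter). All three remain within the scatter, so none points in a direction. Within the data shown here, no measured compound contains the 3-hydroxypiperidin-1-yl group, which leaves real uncertainty.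

The expected change, a 1.1-fold higher number from compound 3 to compound 4 (0.04 log units; within the scatter), is therefore no step beyond the scatter in this assay. Compound 4 is estimated at 5000 nM, with an expected range of 1800 nM to 12000 nM.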

Compound 4, half-maximal inhibitory concentration: 1340 nM
Compound 4: the middle estimate sits 3.7-fold (0.57 log units) above what was measured; the whole stated range lies above it.
By their numbers in this assay, from the lowest: compound 4; then compounds 3, 2 and 1 (each within the scatter of the next).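

In this assay, the group on this nitrogen can shift the number after all: the earlier exchanges stayed within the scatter, but ((3-hydroxypiperidin-1-yl)methyl)carbonyl gives a 3.4-fold lower number from compound 3 to compound 4 (0.53 log units; beyond the scatter) and a 3.6-fold lower number from compound 2 to compound 4 (0.56 log units; beyond the scatter). The carbonyl alone does not account for this, since compound 1 also carries a carbonyl on this nitrogen, and replacing only its cyclohexyl with (3-hydroxypiperidin-1-yl)methyl still gives a 4.9-fold lower number from compound 1 to compound 4 (0.69 log units; beyond the scatter). No measurement offered here explains why this group gives the lower number.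

The compounds shown leave open which part of the entering group matters, the hydroxyl, the ring nitrogen or the methyl link between ring and carbonyl. A plain piperidin-1-yl or a morpholin-4-yl on the same methylcarbonyl would begin to separate these parts.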